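Trimming a methyl from an ester side chain

A few compounds are considered here, and "the series" means these few. Any claim that something is new, unique, unknown or untested is made for them only; others in the source may bear on it.

Measured compounds:
- compound 3 `CCOC(=O)C(C)Oc1cc(O)c2c(=O)c(O)c(-c3ccc(OC)cc3)oc2c1CC=C(C)C`: 1400 nM
- compound 1 `CCOC(=O)COc1c(-c2ccc(OC)cc2)oc2c(CC=C(C)C)c(O)cc(O)c2c1=O`: "not determined" (no result reported)
- compound 2 `COc1ccc(-c2oc3c(CC=C(C)C)c(OC(C(=O)O)C(=O)O)cc(O)c3c(=O)c2OC(C(=O)O)C(=O)O)cc1`: "not determined" (no result reported)

Three compounds from this study share a flavone-type core carrying a methoxyphenyl group and a prenyl chain, and differ in the side chain attached through an oxygen on the aromatic ring. In an ADME assay on Vero cells (Chlorocebus sabaeus) for cytotoxicity, read by MTT assay (on this read-out lower numbers stand for stronger inhibition and higher numbers for weaker inhibition), compound 3 gives 1400 nM. In this assay, going by the values given here, compound 1 gives "not determined" (no result reported) and compound 2 gives "not determined" (no result reported), so compound 3 stands alone as the only compound with a measured value; there is nothing to compare it with.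

Compound 4 `CCOC(=O)COc1cc(O)c2c(=O)c(O)c(-c3ccc(OC)cc3)oc2c1CC=C(C)C` has not yet been measured. It differs from compound 3 by hydrogen in place of methyl on a saturated chain carbon bound to a carbonyl carbon and an oxygen on an aromatic ring, a small trimming of the ester side chain rather than an exchange of one group for another. Among the compounds with values here, no pair of measured compounds shows what such a change does here, so the expectation rests on the size of the change alone.

For a change this small, the step from compound 3 to compound 4 is expected to be a 1.1-fold higher number from compound 3 to compound 4 (0.06 log units; within the scatter) in this assay, that is, none beyond the scatter. Compound 4 is therefore estimated at 1600 nM, within a range of 700 nM to 4000 nM.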

Compound 4, half-maximal inhibitory concentration: 1400 nM
Estimate against measurement, compound 4: 1.1-fold (0.06 log units) above; measured number inside the range.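

Going by these compounds alone, the pair gives the first direct look at this position. In this assay, hydrogen in place of methyl on a saturated chain carbon bound to a carbonyl carbon and an oxygen on an aromatic ring gives no change at the digits printed from compound 3 to compound 4 (within the scatter), so going from 1-(ethoxycarbonyl)ethoxy to (ethoxycarbonyl)methoxy makes no difference that can be told from ordinary repeat-to-repeat variation, and for these two compounds the methyl is not needed to hold the number at this level. Nothing shown here speaks to a cause for this result.

A change as small as one methyl says little about larger ones: these compounds cannot tell whether a longer chain such as propyl or an amine on this same carbon would move the number, or whether an amide in place of the ethyl ester would. Going by these compounds, compound 3 and compound 4 also share the prenyl chain and the methoxyphenyl group, so what those parts contribute to the number stays open.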